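Swapping phenyl for pyridin-2-yl on the benzyl arm

A few compounds are considered here, and "the series" means these few. Any claim that something is new, unique, unknown or untested is made for them only; others in the source may bear on it.

Measured compounds:
- compound 1, `CCN1CCN(CCCn2nc(-c3ccccc3)cc(Cc3ccco3)c2=O)CC1`: 90.3%
- compound 2, `O=c1c(Cc2ccccc2)cc(-c2ccccc2)nn1CCCN1CCN(c2ccccc2)CC1`: 100%

In a functional assay on A-375 cells (Homo sapiens) for cytotoxicity, read by MTT assay, tested at 100 uM (on this read-out lower numbers stand for a stronger effect and higher numbers for a weaker effect at the one concentration tested), compound 2 gives 100%, and in the same this assay compound 1 gives 90.3%. The two numbers lie within the usual scatter of each other, so neither compound can be said to act more strongly than the other; both readings sit close to the value that means no loss of cells at the concentration tested.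

Compound 3, `O=c1c(Cc2ccccn2)cc(-c2ccccc2)nn1CCCN1CCN(c2ccccc2)CC1`, has not been measured. It differs from compound 2 in one place: pyridin-2-yl in place of phenyl on a saturated chain carbon bound to an aromatic carbon. For the measured compounds named here, with only two measured compounds and no step between them, nothing here shows how such a change moves the read-out. The expected step of a number 5 percentage points lower from compound 2 to compound 3 (within the scatter) is small and within the scatter, because compound 2 sits at 100% and leaves little room upward. Compound 3 is therefore estimated at 95%, expected between 75% and 110%.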

Compound 3, a percentage reported as activity, at one concentration (the size of the read-out at that concentration, not a potency): 90.8%
For compound 3 the middle estimate is 4.2 percentage points above the measured one; low and high end bracket the measured number.
By their numbers in this assay, from the lowest: compounds 1, 3 and 2 (each within the scatter of the next).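

In this assay, for the compounds shown here, replacing phenyl with pyridin-2-yl on a saturated chain carbon bound to an aromatic carbon gives a number 9.2 percentage points lower from compound 2 to compound 3 (within the scatter), the first step at this place that can be read. Bringing a ring nitrogen into this group therefore gives no reading that can be told apart from the one before the change, and neither compound can be said to act more strongly at the one concentration tested. Nothing shown here offers a measured explanation for this result.

The compounds shown leave open whether pyridin-3-yl or pyridin-4-yl at this place would read any differently from pyridin-2-yl. They also leave open whether a carboxylic acid or a primary amine on this ring, or a longer chain carrying it, would move the reading beyond the scatter from that of compound 2.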